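This account rests on a few compounds, and the source may have more. Where it says the series, first, only, none or still open, it means among the compounds named here.

In an assay on LtK cells with ATP-sensitive inward rectifier potassium channel 11 (Homo sapiens) as the target (on this read-out higher numbers stand for an effect only at larger amounts of compound and lower numbers for an effect already at smaller amounts), three compounds have been measured: compound 1 `CC(C)C(=O)Nc1c(C(O)(C(F)(F)F)C(F)(F)F)ccc2ccccc12` gives 6630 nM; compound 2 `CC(C)CCC(=O)Nc1c(C(O)(C(F)(F)F)C(F)(F)F)ccc2ccccc12` gives 49 nM; compound 3 `O=C(Nc1c(C(O)(C(F)(F)F)C(F)(F)F)ccc2ccccc12)C1CCC1` gives 45 nM.

Compound 3 carries the lowest of these numbers, yet its gap to compound 2 is within the scatter a 1.1-fold lower number from compound 2 to compound 3 (0.04 log units; within the scatter), so the two cannot be ranked against each other. Compound 4 `O=C(CC1CCCC1)Nc1c(C(O)(C(F)(F)F)C(F)(F)F)ccc2ccccc12` differs from compound 3 in one place: cyclopentylmethyl in place of cyclobutyl on a carbonyl carbon. Among the compounds with values here, two measured steps bear on this change, a 150-fold lower number from compound 1 to compound 3 (2.17 log units; beyond the scatter) and a 140-fold lower number from compound 1 to compound 2 (2.13 log units; beyond the scatter), both large, and both go from the smallest group on the carbonyl carbon to a larger one. Between two larger groups, the step was only a 1.1-fold lower number from compound 2 to compound 3 (0.04 log units; within the scatter). A further enlargement is therefore expected to leave this assay near where compound 3 stands, as an expected step of a 1.1-fold lower number from compound 3 to compound 4 (0.05 log units; within the scatter). Compound 4 is estimated at 40 nM, with a range of 15 nM to 130 nM.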

Compound 4, half-maximal effective concentration: 81 nM
Compound 4: middle estimate off by 2.0-fold (0.31 log units), on the low side; the measured number falls inside the stated range.
By their numbers in this assay, from the lowest: compounds 3, 2 and 4 (each within the scatter of the next); then compound 1.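

With cyclopentylmethyl on the carbonyl carbon, the number in this assay shows a 1.8-fold higher number from compound 3 to compound 4 (0.26 log units; within the scatter) and a 1.7-fold higher number from compound 2 to compound 4 (0.22 log units; within the scatter), so compound 4 cannot be told apart from either neighbour. This position therefore accepts a third, differently shaped group at the same level, while the large separation from the isopropyl group remains, with an 82-fold lower number from compound 1 to compound 4 (1.91 log units; beyond the scatter). Nothing available explains these numbers. Still open, going by these compounds, is whether a longer chain, a phenyl ring, an amine or a carboxylic acid on this carbonyl carbon would stay at this level in this assay.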